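This account rests on a few compounds, and the source may have more. Where it says the series, first, only, none or still open, it means among the compounds named here.

Going by the values given here, compound 1 `C=CC(=C)CC[C@@H]1[C@@]2(C)CCC[C@](C)(COC(=O)/C=C/c3ccc(O)cc3)[C@@H]2CC[C@@]1(C)O` is the only member of the series with a numerical result in a functional assay on SMMC-7721 cells (Homo sapiens) for cytotoxicity, read by MTT assay, with a stated time of 48 h; a higher number here means a weaker inhibitor, a lower number a stronger inhibitor: compound 1 gives 15500 nM. Compound 2 `C=C[C@]1(C)O[C@H]1C[C@H]1C(=C)CC[C@@H]2[C@]1(C)CCC[C@]2(C)C(=O)O` returns only a limit of the assay in this assay, > 40000 nM. Compound 3 `C=C1CC[C@@H]2[C@](C)(CCC[C@@]2(C)C(=O)O)[C@H]1CC/C(C)=C/COC(C)=O` likewise returns only a limit, > 40000 nM. The series thus clusters at the limit of > 40000 nM in this assay, at which 2 of the 3 values shown sit, leaving compound 1 alone with a number. Compound 4 `C=CC(=C)CC[C@@H]1[C@@]2(C)CCC[C@](C)(COC(=O)/C=C\c3ccc(O)cc3)[C@@H]2CC[C@@]1(C)O` is not yet measured and differs from compound 1 only in configuration: the two compounds have the same atoms and bonds and differ only in configuration as drawn: 1 of 6 stereo elements differ; a double bond is drawn E in compound 1 and Z in compound 4. Among the compounds with values here, no measured pair shares this kind of change, so the step from compound 1 to compound 4 in this assay is expected to be small, in no firm direction and probably within the scatter, a 1.2-fold higher number from compound 1 to compound 4 (0.06 log units; within the scatter). Compound 4 is therefore estimated at 18000 nM, with a range from 7000 nM to 40000 nM.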

Compound 4, half-maximal inhibitory concentration: 16200 nM
Compound 4: the middle estimate sits 1.1-fold (0.05 log units) above what was measured; measured number inside the range.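

In this assay, moving the double bond from E to Z leaves the number effectively in place, with a 1.0-fold higher number from compound 1 to compound 4 (0.02 log units; within the scatter). This is the first readable step in the series, and it isolates configuration at this double bond alone: the fact that compounds 1 and 4 differ only in the configuration as drawn The other compounds yield no steps, and their results are limits of the assay: the limit of > 40000 nM in this assay, at which 2 of the 4 values shown sit.

Still open, going by these compounds, is whether any change to the side chain of compound 1 can move the number beyond the scatter. An amide in place of the ester, or an amine in place of the phenol hydroxyl, would test this.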